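From an aryl group to cyclopropyl at the carbonyl

This account rests on a few compounds, and the source may have more. Where it says the series, first, only, none or still open, it means among the compounds named here.

Measured in a functional assay on HT-29 cells (Homo sapiens) for inhibition, read by MTT assay, with a stated time of 48 h (on this read-out lower numbers stand for stronger inhibition and higher numbers for weaker inhibition), each value a limit:
compound 1 `CCSc1nnc(-c2cc(OC)c(OC)c(OC)c2)n1-c1ccc(OC)cc1` gives > 60000 nM
compound 2 `COc1ccc(CSc2nnc(-c3cc(OC)c(OC)c(OC)c3)n2-c2ccc(OC)cc2)cc1` gives > 60000 nM
compound 3 `COc1ccc(-n2c(SCC(=O)c3ccc(OC)c(O)c3)nnc2-c2cc(OC)c(OC)c(OC)c2)cc1` gives > 60000 nM

Compound 3 gives no number, only the limit > 60000 nM in this assay and so does every other compound measured here. The whole picture is the limit of > 60000 nM in this assay, at which 3 of the 3 values shown sit, and nothing finer.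

Compound 4 `COc1ccc(-n2c(SCC(=O)C3CC3)nnc2-c2cc(OC)c(OC)c(OC)c2)cc1` differs from compound 3 in one group, cyclopropyl in place of 3-hydroxy-4-methoxyphenyl on a carbonyl carbon and in words this is cyclopropyl in place of 3-hydroxy-4-methoxyphenyl on a carbonyl carbon.

Three measured steps alter the same chain, namely a step that the two limits leave unreadable from compound 1 to compound 2 and a step that the two limits leave unreadable from compound 1 to compound 3 and a step that the two limits leave unreadable from compound 2 to compound 3 and none of them has a size that can be read. They give no direction for the new change. Going by compound 3 at the limit > 60000 nM as its only reading, compound 4 is expected to remain in the same region. The expected move is a number no higher from compound 3 to compound 4 (the limit leaves the size open) in this assay with no step beyond the scatter foreseen. The estimate for compound 4 is 60000 nM with an expected range of 15000 nM to 120000 nM in this test.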

Compound 4, half-maximal inhibitory concentration: > 60000 nM
Compound 4: a limit, no number; the forecaster's own chance of this, stated with the estimate: 75%; the middle value lies on the limit itself.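

The steps from compound 1, compound 2 and compound 3 to compound 4 cannot be read, since all four compounds give only a limit and no number: the limit of > 60000 nM in this assay, at which 4 of the 4 values shown sit. The compounds shown leave open whether any of these changes on the chain alters inhibition at all.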